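A few compounds are considered here, and "the series" means these few. Any claim that something is new, unique, unknown or untested is made for them only; others in the source may bear on it.

Measured compounds:
- compound 1 `O=C(CSc1nnnn1-c1ccccc1)N/N=c1/scc(-c2ccc(Cl)cc2)n1-c1ccccc1`, 69.3% in a functional assay on C6 cells (Rattus norvegicus) for cytotoxicity, read by MTT assay, with a stated time of 24 h, tested at 12 ug/mL; a higher number here means a weaker effect of the compound at the concentration tested, a lower number a stronger effect
- compound 2 `O=C(CSc1ncccn1)N/N=c1/scc(-c2ccc(Br)cc2)n1-c1ccccc1`, 72.1% in this assay

Compound 2 gives the numerically higher of the two values, but compound 1 sits within the usual scatter of it, so the two compounds are not distinguished by these numbers. For the measured compounds named here, compound 1 and compound 2 differ in more than one place, and no single step between them is available; only the two values themselves can be read.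

The next compound, compound 3 `O=C(CSc1ncccn1)N/N=c1/scc(-c2ccc(Cl)cc2)n1-c1ccccc1`, is not yet measured in this assay. It is built from compound 2 by a single change: chloro in place of bromo on an aromatic carbon. Nothing in the measured pair shows how a change of this kind moves the read-out on its own, since compound 1 carries the chloro together with a different linker. The change is small in what it adds and removes, and the expectation is a step of no more than the scatter in either direction, with the read-out staying near that of compound 2. On this basis the step from compound 2 to compound 3 is expected to be a number 2.1 percentage points lower from compound 2 to compound 3 (within the scatter). Compound 3 is estimated at 70%, within a range of 58% to 82%.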

Compound 3, a percentage reported as activity, at one concentration (the size of the read-out at that concentration, not a potency): 91.6%
Compound 3: the middle estimate sits 21.6 percentage points below what was measured, and the stated range ends below it.
By their numbers in this assay, from the lowest: compounds 1 and 2 (each within the scatter of the next); then compound 3.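

In this assay, with pyrimidin-2-yl held on the sulfur, 4-bromophenyl to 4-chlorophenyl gives a number 19.5 percentage points higher from compound 2 to compound 3 (beyond the scatter), so the halogen on this aromatic carbon, para to a large group, can shift the read-out beyond the scatter and toward a weaker effect at the concentration tested, which the earlier pair could not show. With chloro held in place, pyrimidin-2-yl in place of 1-phenyl-1H-tetrazol-5-yl on the sulfur gives a number 22.3 percentage points higher from compound 1 to compound 3 (beyond the scatter), so the group on the sulfur matters as well, even though compound 1 and compound 2, which differ in more than one place, lie within the scatter of each other and gave no hint of either effect. No measured evidence here accounts for either step.

Going by these compounds, it remains open whether the change from bromo to chloro moves the read-out the same way when 1-phenyl-1H-tetrazol-5-yl sits on the sulfur, so the step may belong to this pyrimidin-2-yl pair alone. Also open, on these data alone, is how a fluoro, a methoxy or an amine on the same aromatic carbon would read against chloro and bromo.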